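From Compound 3 to Compound 4: A Halogen Returns

A few compounds are considered here, and "the series" means these few. Any claim that something is new, unique, unknown or untested is made for them only; others in the source may bear on it.

Of the compounds shown here, three built on a shared core have been tested in a functional assay on MCF7 cells (Homo sapiens) for antiproliferative activity, read by MTT assay, with a stated time of 72 h; a higher number here means a weaker inhibitor, a lower number a stronger inhibitor. Compound 1 `O=C(COc1ccc(C(=O)/C=C/c2cccc(Cl)c2)cc1)N[C@H]1CCOC1=O` gives 20900 nM in this assay, and compound 2 `O=C(COc1ccc(C(=O)/C=C/c2ccc(Cl)cc2Cl)cc1)N[C@H]1CCOC1=O` gives 34400 nM. Compound 3 `COc1ccccc1/C=C/C(=O)c1ccc(OCC(=O)N[C@H]2CCOC2=O)cc1` reaches only a limit of this assay, > 64000 nM. Among the compounds with values here, compound 3 is thus the one member with a limit rather than a number: the step of an at least 3.0-fold higher number from compound 1 to compound 3 (0.48 log units; beyond the scatter) lies beyond the scatter, whereas a 1.6-fold higher number from compound 1 to compound 2 (0.22 log units; within the scatter) and an at least 1.8-fold higher number from compound 2 to compound 3 (0.26 log units; that floor lies within the scatter) do not, the last resting on (the limit of > 64000 nM in this assay, at which 1 of the 3 values shown sits). Compound 4 `O=C(COc1ccc(C(=O)/C=C/c2ccc(F)cc2)cc1)N[C@H]1CCOC1=O` differs from compound 3 by a single change: 4-fluorophenyl in place of 2-methoxyphenyl on a double-bonded chain carbon bound to a double-bonded chain carbon. Of the measured steps, only the two that exchange 3-chlorophenyl or 2,4-dichlorophenyl for 2-methoxyphenyl bear on this change, and both ran toward higher numbers. Compound 4 is therefore expected to move back toward a lower number, a step of about an at least 2.2-fold lower number from compound 3 to compound 4 (0.35 log units; beyond the scatter). Compound 4 is accordingly estimated at 28000 nM in this assay, with a range from 11000 nM to 70000 nM.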

Compound 4, half-maximal inhibitory concentration: > 64000 nM
Compound 4: no number, only a limit; the forecaster's own chance of this, stated with the estimate: 25%; at least 2.2-fold (0.35 log units) between middle value and limit.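

In this assay compound 4 gives > 64000 nM, which is a limit and not a number. This shows that a halogen at this place does not by itself return a readable value: of the four groups shown on a double-bonded chain carbon bound to a double-bonded chain carbon, only 3-chlorophenyl and 2,4-dichlorophenyl give numbers, with an at least 3.0-fold higher number from compound 1 to compound 4 (0.48 log units; beyond the scatter) and an at least 1.8-fold higher number from compound 2 to compound 4 (0.26 log units; that floor lies within the scatter). The step from compound 3 to compound 4 cannot be read, because both compounds rest on the same limit: the limit of > 64000 nM in this assay, at which 2 of the 4 values shown sit.

Going by these compounds, whether 4-fluorophenyl and 2-methoxyphenyl differ at all beyond that limit remains open. Also open, on these data alone, is whether the chlorine atom or where it sits carries the difference, and a 4-chlorophenyl group at this place would bear directly on that question.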